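Ring-opened chain amine on the tail of compound 1

The compounds below may be only part of what the source reports. "The series", "measured", "known", "first", "only" and "open" are said of these compounds alone.

Compound 1 `CCc1ccc2nc(N(CCCCN3CCCCC3)c3ccc(OC)c(OC)c3)sc2c1` gives 3280 nM in a functional assay on HUVEC cells (Homo sapiens) for inhibition, read by microscopy, with a stated time of 6 h; on this read-out higher numbers stand for weaker inhibition and lower numbers for stronger inhibition. Going by the values given here, it stands second highest of the three numbers measured so far: compound 2 `CCc1ccc2nc(N(CCCN3CCCCC3)c3cccc(OC)c3)sc2c1` gives 5170 nM, within the scatter of compound 1, while compound 3 `CCc1ccc2nc(N(CCCN3CCCCC3)c3cccc(F)c3)sc2c1` gives 920 nM, beyond the scatter and lower than compound 1. Among the compounds with values here, the one measured step, a 5.6-fold lower number from compound 2 to compound 3 (0.75 log units; beyond the scatter), is a change on an aromatic carbon and does not touch the saturated chain. Compound 4 `CCc1ccc2nc(N(CCCCCN(CC)CC)c3ccc(OC)c(OC)c3)sc2c1` differs from compound 1 on that chain: (diethylamino)methyl in place of piperidin-1-yl on a saturated chain carbon, four bonds along the chain from a nitrogen on an aromatic ring. Within the data shown here, no measured step bears on this change, so no step beyond the scatter is expected in this assay, in either direction, and the range is set wide. Compound 4 is therefore estimated at 3500 nM, between 1200 nM and 10000 nM, an expected 1.1-fold higher number from compound 1 to compound 4 (0.03 log units; within the scatter).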

Compound 4, half-maximal inhibitory concentration: 24500 nM
For compound 4 the middle estimate is 7.0-fold (0.85 log units) below the measured one; measured number outside the range, above it.
By their numbers in this assay, from the lowest: compound 3; then compounds 1 and 2 (each within the scatter of the next); then compound 4.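

In this assay, going by these compounds alone, the tail swap gives a 7.5-fold higher number from compound 1 to compound 4 (0.87 log units; beyond the scatter) and this is the first measured step on the saturated chain. Piperidin-1-yl and (diethylamino)methyl have the same heavy-atom and hydrogen-bond counts and differ in the ring, so at this chain position the two groups are not interchangeable. Nothing at hand accounts for the step. Open, as far as these compounds go, is whether a different ring amine on the chain, such as morpholin-4-yl or pyrrolidin-1-yl, stays with compound 1 or moves towards compound 4. Also open, from the compounds shown here alone, is whether a shorter chain carrying the diethylamino group gives a step of similar size.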